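This account rests on a few compounds, and the source may have more. Where it says the series, first, only, none or still open, it means among the compounds named here.

Measured compounds in a functional assay on HCT-116 cells (Homo sapiens) for cytotoxicity, read by MTT assay, with a stated time of 24 h; a lower number here means a stronger inhibitor, a higher number a weaker inhibitor:
compound 1 `O=S(=O)(O)OCCCCCCCC[Te]c1ccccc1` — 5990 nM
compound 2 `O=S(=O)(O)OCCCCCCCC[Se]c1ccccc1` — only a limit, > 100000 nM
compound 3 `O=S(=O)(O)OCCCCCCCCC[Se]c1ccccc1` — only a limit, > 100000 nM

Going by the values given here, compound 1, the tellurium member, is the one compound of the three with a number in this assay. Compound 2 sits at a limit of the assay and not at a number. Compound 3 likewise sits at a limit, so its standing on the numbers is known only as the limit of > 100000 nM in this assay, at which 2 of the 3 values shown sit. Among the compounds with values here, the step that the two limits leave unreadable from compound 2 to compound 3 is the one measured step that bears on the present change, and its size cannot be read from the two limits.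

Compound 4 `O=S(=O)(O)OCCCCCCCCCCC[Se]c1ccccc1` differs from compound 3 by 2-(sulfooxy)ethyl in place of sulfooxy on a saturated chain carbon, nine bonds along the chain from a selenium atom. This is the same kind of lengthening of the chain between the selenium atom and the sulfooxy group as in the step from compound 2 to compound 3, where both members stayed at the limit. Compound 4 is therefore expected to remain at the limit as well, a step that the limit leaves unreadable from compound 3 to compound 4 being expected rather than any readable gain. The estimate for compound 4 is 150000 nM, with a range of 50000 nM to 500000 nM.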

Compound 4, half-maximal inhibitory concentration: > 100000 nM
Compound 4: only a limit was reported; the forecaster's own chance of this, stated with the estimate: 85%; the middle value is on the limit's open side.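

In this assay compound 4 gives > 100000 nM, a limit and not a number. Compound 3 also sits at a limit, so no step between compound 3 and compound 4 can be read: the limit of > 100000 nM in this assay, at which 3 of the 4 values shown sit.

The compounds shown leave open whether any selenium member gives a number in this assay, and how chain length bears on the tellurium member, compound 1.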